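Fluoro to Iodo: One Halogen Swap, Measured and Expected

The compounds below may be only part of what the source reports. "The series", "measured", "known", "first", "only" and "open" are said of these compounds alone.

Four compounds share most of their skeleton and differ in two places: the halogen on an aromatic carbon and the chain that links the two parts. Compound 1 is `O=C1C(=O)N(CCCCCn2cc(COc3cc(=O)oc4ccccc34)nn2)c2ccc(F)cc21`. Compound 2 is `O=C1C(=O)N(CCCCCn2cc(COc3cc(=O)oc4ccccc34)nn2)c2ccc(I)cc21`. Compound 3 is `O=C1C(=O)N(CCCCn2cc(COc3cc(=O)oc4ccccc34)nn2)c2ccc(F)cc21`, and compound 4 is `O=C1C(=O)N(CCCCn2cc(COc3cc(=O)oc4ccccc34)nn2)c2ccc(I)cc21`. How the core of compound 3 differs from the core of compound 1 is not broken down here.

Three of them have been tested in a functional assay on COLO 205 cells (Homo sapiens) for inhibition, read by sulforhodamine B assay, with a stated time of 48 h, tested at 50 uM; a lower number here means less inhibition of growth, a higher number more inhibition of growth at the concentration tested. In this assay compound 1 gives 56% and compound 2 gives 30%, while compound 3 gives 64%. Among the compounds with values here, the single change from compound 1 to compound 2 is iodo in place of fluoro on an aromatic carbon. Its effect in this assay is a number 26 percentage points lower from compound 1 to compound 2 (beyond the scatter). Compound 3 and compound 1 lie within the scatter of each other, so nothing can be said about their order, whereas compound 3 and compound 2 sit beyond the scatter apart.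

Compound 4 carries the same change applied to compound 3: iodo in place of fluoro on an aromatic carbon. The place is described in identical words for both pairs, so this is the same change, not merely the same kind of change. Within the data shown here, the step expected in this assay is a number 26 percentage points lower from compound 3 to compound 4 (beyond the scatter), resting on the single measured example, a number 26 percentage points lower from compound 1 to compound 2 (beyond the scatter). Among the measured compounds shown here, with only one such example, the expectation is loose.

For compound 4 the estimate in this assay is 38%. For compound 4 the expected range runs from 22% to 54%.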

Compound 4, percent growth inhibition at one concentration: 50%
For compound 4 the middle estimate is 12 percentage points below the measured one; low and high end bracket the measured number.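

In this assay, the swap of fluoro for iodo on the second core moves the result the same way as it did on the first, and the measured change is a number 14 percentage points lower from compound 3 to compound 4 (beyond the scatter). So this one change carries from one core to the other in direction, and although the two steps differ on paper, their sizes cannot be told apart: the same change on two cores in this assay, a number 26 percentage points lower (beyond the scatter) from compound 1 to compound 2 and a number 14 percentage points lower (beyond the scatter) from compound 3 to compound 4, 12 percentage points apart, within the scatter of two such steps. This does not show that the second core softens the effect of iodo, it does not explain why iodo lowers growth inhibition in these compounds, and two pairs are too few to promise the same step on any core outside these four compounds.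

The compounds shown carry only fluoro or iodo at this place on the aromatic ring, so it remains open how chloro, bromo or a plain hydrogen there would compare, and whether the step would hold with a longer chain linking the two parts. On these data alone, each number is also a reading at a single concentration, so it remains open whether the same ranking would appear across a full range of concentrations or in other cell lines.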